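A large new group on a thiourea series

The source may report more compounds than this note shows. Statements on the series, on what has been measured and on what is new or still open speak of the compounds shown alone.

- Compound 1 `FC(F)(F)c1cccc(NC(=S)Nc2ccc(I)cc2)c1` gives 10000 nM
- Compound 2 `FC(F)(F)c1cccc(NC(=S)Nc2ccc(Cl)cc2)c1` gives 6800 nM
- Compound 3 `O=[N+]([O-])c1ccc(NC(=S)Nc2cccc(C(F)(F)F)c2)cc1` gives 9200 nM

All three compounds were tested in an ADME assay on MT4 cells (Homo sapiens) for cytotoxicity; on this read-out lower numbers stand for higher toxicity in this test and higher numbers for lower toxicity in this test. There, compound 3 gives 9200 nM, which cannot be told apart from the other two numbers. The comparisons are a 1.1-fold lower number from compound 1 to compound 3 (0.04 log units; within the scatter) and a 1.4-fold higher number from compound 2 to compound 3 (0.13 log units; within the scatter).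

Compound 4 `CCCC[C@H]1CC[C@H](c2ccc(NC(=S)Nc3cccc(C(F)(F)F)c3)cc2)CC1` has 4-butylcyclohexyl in place of nitro on an aromatic carbon. The new group brings a six-membered non-aromatic ring of carbon only and two defined stereocentres.

Among the measured compounds shown here, three measured steps bear on this change, since each swaps one group on an aromatic carbon for another. Besides the two above, there is a 1.5-fold lower number from compound 1 to compound 2 (0.17 log units; within the scatter). Swapping among iodo, chloro and nitro therefore left this assay within the scatter. For the measured compounds named here, none of those swaps brought in a ring or a group of this size, so they are only a weak guide, and the data hold no direct precedent for the change.

With no measured step beyond the scatter, no clear shift is expected, although the uncertainty is wide. The expected change is a 1.2-fold lower number from compound 3 to compound 4 (0.06 log units; within the scatter). For compound 4 the estimated value is 8000 nM, within an expected range from 3000 nM to 20000 nM.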

Compound 4, half-maximal cytotoxic concentration: 22000 nM
Estimate against measurement, compound 4: 2.8-fold (0.44 log units) below; the whole stated range lies below it.
By their numbers in this assay, from the lowest: compounds 2, 3 and 1 (each within the scatter of the next); then compound 4.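

In this assay, this position had shown no readable response to swaps among iodo, chloro and nitro, but 4-butylcyclohexyl does move the number beyond the scatter, with a 2.4-fold higher number from compound 3 to compound 4 (0.38 log units; beyond the scatter). The same holds against the other two compounds, with a 3.2-fold higher number from compound 2 to compound 4 (0.51 log units; beyond the scatter) and a 2.2-fold higher number from compound 1 to compound 4 (0.34 log units; beyond the scatter), so all three steps point towards lower toxicity in this test, though each is only modest in size. Nothing in the data accounts for this shift, and no measurement of any property of these compounds is available to link it to the new group.

The single change brings in a six-membered ring, a butyl chain and two defined stereocentres together, so the compounds shown leave open which of these goes with the higher number. A plain butyl chain or an unsubstituted cyclohexyl on the same aromatic carbon would begin to separate these parts, while an amine or a carboxylic acid in that place would show whether the result extends beyond groups made of carbon only.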